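The compounds below may be only part of what the source reports. "The series", "measured", "known", "first", "only" and "open" are said of these compounds alone.

Measured so far in an ADME assay on Raji cells (Homo sapiens) for cytotoxicity, with a stated time of 72 h; a higher number here means that more compound is needed for the effect, a lower number that less compound is needed:
- Compound 1 `Cc1cc(NC(=O)Nc2ccc(C)c(Cl)c2)c2ccccc2n1`: > 25000 nM, a limit
- Compound 2 `Cc1ccc(NC(=O)Nc2cc(C)nc3ccccc23)cc1`: > 25000 nM, a limit

Compound 2 has no numerical value, only the limit > 25000 nM. Compound 3 `Cc1cc(NC(=O)Nc2ccc(OC(F)(F)F)cc2)c2ccccc2n1` differs from it by trifluoromethoxy in place of methyl on an aromatic carbon. Going by the values given here, the only measured step, a step that the two limits leave unreadable from compound 1 to compound 2, offers no size to carry over. The evidence so far is the limit of > 25000 nM in this assay, at which 2 of the 2 values shown sit. In this assay, the step is estimated as a number no higher from compound 2 to compound 3 (the limit leaves the size open), so none beyond the scatter is expected. For compound 3 the estimate is 25000 nM, with an expected range from 8000 nM to 50000 nM.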

Compound 3, half-maximal effective concentration: 10000 nM
Compound 3: the middle estimate sits 2.5-fold (0.40 log units) above what was measured, within the range that was stated.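

In this assay, going by these compounds alone, the place para to a large group is the first where a change can be read: trifluoromethoxy in place of methyl gives an at least 2.5-fold lower number from compound 2 to compound 3 (0.39 log units; beyond the scatter) and brings a measured number into the series. This size is only a minimum, because compound 2 carries a limit and not a number: the limit of > 25000 nM in this assay, at which 2 of the 3 values shown sit.

On these data alone, whether this number depends on trifluoromethoxy itself remains open, since methoxy or trifluoromethyl at this place would separate the oxygen from the fluorines. An amine or a carboxylic acid there also remains untested among the compounds shown.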